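The source may report more compounds than this note shows. Statements on the series, on what has been measured and on what is new or still open speak of the compounds shown alone.

Compound 3 `CC(C(=O)N1CCN(c2ccc(Cl)cc2)CC1)N1C(=O)CCC1=O` is one of three measured members of a small series built around a shared core. In a functional assay on the whole organism (strain Swiss) with Mus musculus as the target, in the maximal electroshock model, with a stated time of 1 h, at a dose of 300 mg/kg by the intraperitoneal route (on this read-out lower numbers stand for a weaker effect and higher numbers for a stronger effect at the one dose given), compound 3 gives 0%. Compound 2 `COc1cccc(N2CCN(C(=O)C(C)N3C(=O)CCC3=O)CC2)c1` gives 0% in this assay, so the two stand level and together at the bottom of the measured set. Compound 1 `CCC(C(=O)N1CCN(c2ccccc2F)CC1)N1C(=O)CCC1=O` gives 50% in this assay, a number well beyond the scatter above compound 3.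

The unmeasured compound 4 `CC(C(=O)N1CCN(c2ccccc2F)CC1)N1C(=O)CCC1=O` differs from compound 3 in one place: 2-fluorophenyl in place of 4-chlorophenyl on an amine nitrogen in a ring. For the measured compounds named here, the only measured step that changes the group on the same ring nitrogen is the one from compound 2 to compound 3, which gave no change at the digits printed from compound 2 to compound 3 (within the scatter). That step suggests swapping one substituted phenyl for another need not move the read-out. Going by the values given here, compound 1, however, carries the same 2-fluorophenyl that enters here and is the only compound with a clear effect, though it also differs from compound 4 in its side chain, and no step for that pair has been measured. The expectation is therefore a modest rise, with wide uncertainty: compound 4 is estimated at 25%, between 0% and 60%, which means an expected step of a number 25 percentage points higher from compound 3 to compound 4 (beyond the scatter) from compound 3.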

Compound 4, a percentage reported as activity, at one dose (the size of the read-out at that dose, not a potency): 50%
Compound 4: the middle estimate sits 25 percentage points below what was measured, within the range that was stated.
By their numbers in this assay, from the lowest: compounds 2 and 3 (each within the scatter of the next); then compounds 1 and 4 (each within the scatter of the next).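

In this assay, the group on the amine nitrogen in a ring turns out to matter: 2-fluorophenyl in place of 4-chlorophenyl gives a number 50 percentage points higher from compound 3 to compound 4 (beyond the scatter), and 2-fluorophenyl in place of 3-methoxyphenyl gives a number 50 percentage points higher from compound 2 to compound 4 (beyond the scatter). The earlier swap of one substituted phenyl for another gave no change at the digits printed from compound 2 to compound 3 (within the scatter), so that step alone gave no sign of what this position can do; among these compounds, the two with an effect are the two that carry 2-fluorophenyl, and none goes against this. For the compounds shown here, the side chain, by contrast, shows no effect in the one pair that can be read, with hydrogen in place of methyl on a saturated chain carbon giving no change at the digits printed from compound 1 to compound 4 (within the scatter), so the effect in compound 1 can be tied to the 2-fluorophenyl rather than to its longer side chain.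

No data are at hand that explain why 2-fluorophenyl stands apart from the other two groups. From the compounds shown here alone, it remains open whether a plain phenyl, a 2-chlorophenyl or a 4-fluorophenyl on the same nitrogen would give the same read-out, which would help show whether the fluorine or its place on the ring counts.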